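The source may hold more compounds than are shown below. What is called first, only, known or untested is meant among the compounds shown, and "the series" means these compounds.

Measured so far in a functional assay on Ehrlich cells (Mus musculus) for cytotoxicity, tested at 50 ug/mL; a lower number here means a weaker effect, a higher number a stronger effect of the compound at the concentration tested:

Compound 1 `COc1cc(N2C(N)=C(C#N)C(c3ccc(Cl)cc3Cl)C3=C2CC(C)(C)CC3=O)cc(OC)c1OC` gives 95%.
Compound 2 `COc1cc(N2C(N)=C(C#N)C(c3ccccc3Cl)C3=C2CC(C)(C)CC3=O)cc(OC)c1OC` gives 20%.

Among the compounds with values here, compound 2 is the lower of the two numbers; its nearest neighbour is compound 1, and the step of a number 75 percentage points lower from compound 1 to compound 2 (beyond the scatter) is the only measured step. That step is a single change at the aromatic ring: hydrogen in place of chloro on an aromatic carbon.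

Compound 3 `COc1cc(N2C(N)=C(C#N)C(c3ccc(C)o3)C3=C2CC(C)(C)CC3=O)cc(OC)c1OC` differs from compound 2 as follows: 5-methylfuran-2-yl in place of 2-chlorophenyl on a saturated ring carbon. This is not a substituent change on a ring that stays; the whole 2-chlorophenyl leaves and a 5-methylfuran-2-yl enters at the same saturated ring carbon. The step of a number 75 percentage points lower from compound 1 to compound 2 (beyond the scatter) bears on it only loosely, since it shows that the group at this ring carbon can move the read-out by a large amount, but it gives no guidance for a five-membered ring with one hetero atom. No direction can be read from the data.

For compound 3 a step of a number 15 percentage points higher from compound 2 to compound 3 (beyond the scatter) is expected, with a wide range. The estimate for compound 3 is therefore 35%, expected to fall between 10% and 75%.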

Compound 3, a percentage reported as activity, at one concentration (the size of the read-out at that concentration, not a potency): 41%
Beside the measured number, compound 3's estimate is 6 percentage points below it; the measured number falls inside the stated range.
By their numbers in this assay, from the lowest: compound 2; then compound 3; then compound 1.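

In this assay, the group on the saturated ring carbon can be exchanged as a whole, not only altered by a chloro: 5-methylfuran-2-yl in place of 2-chlorophenyl gives a number 21 percentage points higher from compound 2 to compound 3 (beyond the scatter), while the same group in place of 2,4-dichlorophenyl gives a number 54 percentage points lower from compound 1 to compound 3 (beyond the scatter). The same exchange therefore moves the read-out up or down depending on the phenyl group that leaves, and compound 3 ranks above compound 2 and under compound 1, so a chlorinated phenyl is not required for a read-out above that of compound 2, nor does any chlorinated phenyl guarantee one. No measurement at hand accounts for either step.

With a single furan in the series, the contribution of the ring cannot be separated from that of its methyl; furan-2-yl without the methyl, or a thiophene or pyridine ring at the same carbon, would bear on this. Also open, from the compounds shown here alone, is how the chloro atoms of compound 1 act separately, which 4-chlorophenyl at this carbon would address.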